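Urea series: aryl substituent change, compound 2 to compound 3

A few compounds are considered here, and "the series" means these few. Any claim that something is new, unique, unknown or untested is made for them only; others in the source may bear on it.

Measured so far:
compound 1, `COc1ccccc1NC(=O)N[C@H](C)c1ccccc1`: 96%
compound 2, `CC(=O)c1ccccc1NC(=O)N[C@H](C)c1ccccc1`: 89%

In an ADME assay on the whole organism with Oryza sativa as the target, tested at 10 uM (on this read-out lower numbers stand for a stronger effect and higher numbers for a weaker effect at the one concentration tested), compound 2 stands at 89%. For the measured compounds named here, its only measured neighbour is compound 1, which in this assay gives 96%; the step of a number 7 percentage points lower from compound 1 to compound 2 (within the scatter), acetyl in place of methoxy on an aromatic carbon, is the single step recorded so far in this set, and it lies within the scatter.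

Compound 3, `C[C@@H](NC(=O)Nc1ccccc1I)c1ccccc1`, is not yet measured. It differs from compound 2 by iodo in place of acetyl on an aromatic carbon. Going by the values given here, no measured step in the set touches an iodo group, so the only step that bears on this change at all is a number 7 percentage points lower from compound 1 to compound 2 (within the scatter), which shows that replacing one substituent at this position of the shared core by another moved this assay by no more than the scatter. On that basis the step from compound 2 to compound 3 is expected to be a number 1 percentage points higher from compound 2 to compound 3 (within the scatter), that is, none beyond the scatter. For compound 3 in this assay the estimate is therefore 90%, with a range from 78% to 100%.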

Compound 3, a percentage reported as activity, at one concentration (the size of the read-out at that concentration, not a potency): 96%
Beside the measured number, compound 3's estimate is 6 percentage points below it, and the stated range covers the measured number.
By their numbers in this assay, from the lowest: compounds 2, 1 and 3 (each within the scatter of the next).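

In this assay, iodo in place of acetyl on an aromatic carbon gives a number 7 percentage points higher from compound 2 to compound 3 (within the scatter), and iodo in place of methoxy gives no change at the digits printed from compound 1 to compound 3 (within the scatter). For the compounds shown here, the earlier compounds offered only the single step between methoxy and acetyl; these two steps add a substituent of a different kind, with iodine as its 1 heavy atom, against the 3 heavy atoms, the double bond and the hydrogen-bond acceptor of the acetyl it replaces, and at this place on the aromatic ring, ortho to a large group, that exchange still stays within the scatter, so methoxy, acetyl and iodo cannot be ranked here. Nothing available explains why these exchanges leave the read-out within the scatter.

From the compounds shown here alone, every step in this small set stays within the scatter, so it remains open whether any substituent at this place can move the read-out in this assay beyond it. An amine, a carboxylic acid or a longer chain in the same place would test that, and so would a change elsewhere on the shared core.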